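The compounds below may be only part of what the source reports. "The series", "measured", "known", "first", "only" and "open" are said of these compounds alone.

Compound 1 `CC1(C)CC(=O)c2s/c(=N/c3ccc(Cl)cc3)oc2C1` was tested in a functional assay on HCT-15 cells (Homo sapiens) for antiproliferative activity, read by sulforhodamine B assay (a higher number here means a weaker inhibitor of growth, a lower number a stronger inhibitor of growth), where compound 1 gives 3790 nM. Compound 2 `CC1CC(=O)c2s/c(=N/c3ccc(Cl)cc3)oc2C1` differs from it by one change, (hydrogen in place of methyl on a saturated ring carbon), and in this assay compound 2 gives 12200 nM. That change made a 3.2-fold higher number from compound 1 to compound 2 (0.51 log units; beyond the scatter). Compound 3 `CC1(C)CC(=O)c2s/c(=N/c3c(Cl)cc(Cl)cc3Cl)oc2C1` carries a different aromatic part; how its core differs from the core of compound 1 is not broken down here. In this assay compound 3 gives only a limit, > 30000 nM. The same change is now applied to compound 3 to give compound 4 `CC1CC(=O)c2s/c(=N/c3c(Cl)cc(Cl)cc3Cl)oc2C1`, namely (hydrogen in place of methyl on a saturated ring carbon). Because compound 3 already sits at the limit of > 30000 nM in this assay, at which 1 of the 3 values shown sits, compound 4 is expected to remain at or beyond that limit, with an expected step that the limit leaves unreadable from compound 3 to compound 4. The estimate for compound 4 in this assay is 70000 nM, ranging from 25000 nM to 300000 nM.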

Compound 4, concentration for 50% growth inhibition: > 30000 nM
Compound 4 gave a limit, no number (the forecaster's own chance of this, stated with the estimate: 85%); the middle value does not contradict the limit.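

Within the data shown here, compound 3 and compound 4 each give only a limit, not a number, so no step between them can be read: the limit of > 30000 nM in this assay, at which 2 of the 4 values shown sit. Still open, as far as these compounds go, is whether hydrogen in place of methyl changes growth inhibition with the aromatic part these two compounds share.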